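Methyl on the pendant phenyl ring: series notes

The compounds below may be only part of what the source reports. "The series", "measured", "known", "first", "only" and "open" are said of these compounds alone.

Measured in a functional assay on the whole organism for inhibition, with Rattus norvegicus as the target, at a dose of 10 mg/kg by the oral route; on this read-out higher numbers stand for a stronger effect at the one dose given and lower numbers for a weaker effect:
compound 1 `CCCc1cc(C(=O)Nc2nn[nH]n2)nc(-c2ccccc2)c1` gives 85%
compound 2 `CCCc1cc(C(=O)Nc2nn[nH]n2)nc(-c2ccc(C)cc2)c1` gives 84%
compound 3 `CCCCc1cc(C(=O)Nc2nn[nH]n2)nc(-c2ccccc2)c1` gives 100%

Compound 2 differs from compound 1 by methyl in place of hydrogen on an aromatic carbon, and the step is a number 1 percentage points lower from compound 1 to compound 2 (within the scatter). The change from propyl to butyl gives a number 15 percentage points higher from compound 1 to compound 3 (beyond the scatter). Compound 3 stands highest of the three, both other values lying beyond the scatter below it.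

Compound 4 `CCCCc1cc(C(=O)Nc2nn[nH]n2)nc(-c2cccc(C)c2)c1` is not yet measured. It differs from compound 3 by methyl in place of hydrogen on an aromatic carbon. This is the same kind of change as that from compound 1 to compound 2, not the same: on compound 2 the methyl sits para to a large group, on compound 4 meta to a large group. The change occurs twice among the compounds shown. The cores of the two pairs differ by methyl in place of hydrogen on a saturated chain carbon, three bonds along the chain from an aromatic carbon.

For compound 4 a step of about the same size is expected, a number 3 percentage points lower from compound 3 to compound 4 (within the scatter), because the same kind of change gave a number 1 percentage points lower from compound 1 to compound 2 (within the scatter). Compound 4 is estimated at 97%, with a range from 85% to 100%.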

Compound 4, a percentage reported as inhibition, in the whole organism at one dose (the size of the read-out at that dose, not a potency): 100%
Compound 4: the middle estimate sits 3 percentage points below what was measured; the measured number falls inside the stated range.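

In this assay, methyl in place of hydrogen on an aromatic carbon gives no change at the digits printed from compound 3 to compound 4 (within the scatter), and the two cores show no detectable difference in how the change carries over: the same change on two cores in this assay, a number 1 percentage points lower (within the scatter) from compound 1 to compound 2 and no change at the digits printed (within the scatter) from compound 3 to compound 4, 1 percentage points apart, within the scatter of two such steps. This does not show a strict transfer of one identical change, since the methyl of compound 4 sits meta to a large group and the methyl of compound 2 does not, so core and position vary together across the two pairs. The read-out is also the size of an effect at one dose rather than a potency, and with compound 4 at 100% the top of the percentage scale is reached, so a gain on this core could not appear.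

The compounds shown leave open whether the result holds for groups other than methyl on the phenyl ring, such as methoxy or chlorine. They also leave open how a longer chain, such as pentyl, would read in this assay.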